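Adding cyclopropyl to the amide nitrogen of compound 2

The source may hold more compounds than are shown below. What is called first, only, known or untested is meant among the compounds shown, and "the series" means these compounds.

Values so far in a functional assay on OVCAR-8 cells (Homo sapiens) for antiproliferative activity (on this read-out higher numbers stand for weaker inhibition and lower numbers for stronger inhibition), are:
- compound 1 `Cn1ncc(Cl)c1-c1cc(C(=O)N[C@@H]2CN[C@H](CCO)C[C@H]2c2ccc(F)c(F)c2)oc1Cl` at 460 nM
- compound 2 `Cn1ncc(Cl)c1-c1cc(C(=O)N[C@@H]2CN[C@H](CC(N)=O)C[C@H]2c2ccc(Cl)c(Cl)c2)oc1Cl` at 1000 nM
- compound 3 `O=C(N[C@@H]1CNCC[C@H]1c1ccc(Cl)cc1)c1ccc(-c2ncnc3c2CCC3O)s1` at 24100 nM

Among these three, compound 2 holds the middle place. Its number is higher than that of compound 1, by a margin beyond the usual scatter, and well below that of compound 3, again beyond the scatter.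

The next compound to be tested is compound 4 `Cn1ncc(Cl)c1-c1cc(C(=O)N[C@@H]2CN[C@H](CC(=O)NC3CC3)C[C@H]2c2ccc(Cl)c(Cl)c2)oc1Cl` in this assay, and it departs from compound 2 in one place. The change is cyclopropyl in place of hydrogen on an amide-type nitrogen, which is cyclopropyl in place of hydrogen on an amide-type nitrogen, turning carbamoylmethyl into (cyclopropylcarbamoyl)methyl.

Within the data shown here, no pair of measured compounds differs in only one place, so the data contain no direct precedent for this change. The expectation therefore rests on the closest measured compounds. Compound 2 at 1000 nM and compound 1 at 460 nM lie much nearer each other than either lies to compound 3 at 24100 nM, which suggests that compound 4 will stay in the same region.

The expected result in this assay is a small move towards a lower number, with the estimated 1.3-fold lower number from compound 2 to compound 4 (0.10 log units; within the scatter) staying within the scatter. Compound 4 is estimated at 800 nM, with an expected range from 250 nM to 2500 nM in this measurement.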

Compound 4, half-maximal inhibitory concentration: 580 nM
Compound 4: middle estimate off by 1.4-fold (0.14 log units), on the high side; the measured number falls inside the stated range.
By their numbers in this assay, from the lowest: compounds 1, 4 and 2 (each within the scatter of the next, the first and the last beyond it); then compound 3.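

Among these compounds, the replacement of hydrogen by cyclopropyl on the amide-type nitrogen gives the first one-place comparison: in this assay, the step reads a 1.7-fold lower number from compound 2 to compound 4 (0.24 log units; within the scatter). Among the compounds shown here, at this position, then, the amide hydrogen of the carbamoylmethyl group can give way to cyclopropyl, forming (cyclopropylcarbamoyl)methyl, with no difference in this read-out that stands clear of the scatter, something the earlier compounds could not show without a matched pair. The data shown offer no independent measurement that would explain this outcome.

As far as these compounds go, this single step speaks only for cyclopropyl, so it remains open whether methyl, isopropyl, phenyl or a second substituent on the same nitrogen would also leave the read-out within the scatter of compound 2. Also open, from the compounds shown here alone, is how a carboxylic acid, an amine or a longer chain in place of the carbamoylmethyl group would read in this assay on the same core, and whether this result would carry over to other substituents on the aromatic ring.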